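Aryl Exchange on a Shared Core: Cytotoxicity Outlook

This account rests on a few compounds, and the source may have more. Where it says the series, first, only, none or still open, it means among the compounds named here.

Compound 1, `COc1ccc(-c2nnc(SCCn3c([N+](=O)[O-])cnc3C)o2)cc1`, in a functional assay on HepG2 cells (Homo sapiens) for cytotoxicity, read by MTT assay, with a stated time of 48 h; a lower number here means a stronger inhibitor, a higher number a weaker inhibitor: 5800 nM
Compound 2, `Cc1ncc([N+](=O)[O-])n1CCSc1nnc(-c2ccccc2F)o1`: 3700 nM

Of the compounds shown here, two have been measured, and they share a core that differs only in the aryl group attached to it. For the measured compounds named here, the one step between them, a 1.6-fold lower number from compound 1 to compound 2 (0.20 log units; within the scatter), does not separate the two beyond the scatter of the method. Compound 2 therefore holds the lower of the two numbers, but that standing carries no weight, since compound 1 sits within the scatter of it.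

Compound 3, `Cc1cccc(-c2nnc(SCCn3c([N+](=O)[O-])cnc3C)o2)c1O`, has not yet been measured. It differs from compound 2 in a single place: 2-hydroxy-3-methylphenyl in place of 2-fluorophenyl on an aromatic carbon. Going by the values given here, the only measured step that bears on an exchange of the aryl group at this position is the one from compound 1 to compound 2, and that step stayed within the scatter. On that evidence alone, no shift beyond the scatter is expected in this assay for compound 3, in either direction. The step from compound 2 to compound 3 is estimated at a 1.2-fold higher number from compound 2 to compound 3 (0.09 log units; within the scatter). Compound 3 is accordingly expected to give about 4500 nM, with a plausible range from 1500 nM to 13000 nM.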

Compound 3, half-maximal inhibitory concentration: 8700 nM
For compound 3 the middle estimate is 1.9-fold (0.29 log units) below the measured one; the range from low to high includes it.
By their numbers in this assay, from the lowest: compounds 2, 1 and 3 (each within the scatter of the next, the first and the last beyond it).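

In this assay, for the compounds shown here, the exchange of 2-fluorophenyl for 2-hydroxy-3-methylphenyl gives a 2.4-fold higher number from compound 2 to compound 3 (0.37 log units; beyond the scatter) and is the only step at this position that passes beyond the scatter, though it remains modest. The same entering group in place of 4-methoxyphenyl gives a 1.5-fold higher number from compound 1 to compound 3 (0.18 log units; within the scatter) and so stays within the scatter, which means that this aryl position has so far separated compound 3 from compound 2 but not from compound 1, and that the exchange at this carbon is not read the same way against both earlier aryl groups. Nothing given here accounts for the step from 2-fluorophenyl to 2-hydroxy-3-methylphenyl.

The entering group brings a hydroxyl and a methyl together, so the compounds shown leave open how each alone would read, which 2-hydroxyphenyl or 3-methylphenyl on the same carbon could settle. They also leave open how far the numbers in this assay would move with an amine or a carboxylic acid on the phenyl ring, or with a longer alkyl chain in place of the aryl group.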